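The source may hold more compounds than are shown below. What is called first, only, known or untested is meant among the compounds shown, and "the series" means these compounds.

Compound 1 `CC#CC1=Nc2ccccc2C(C)(C)O1` and compound 2 `CC#Cc1nc(C(=O)OCC)cs1` both carry a prop-1-yn-1-yl group on cores whose difference is not broken down here. In a functional assay on NCI-H522 cells (Homo sapiens) for cytotoxicity, with a stated time of 3 days (on this read-out lower numbers stand for stronger inhibition and higher numbers for weaker inhibition), compound 1 gives 8400 nM. For compound 2 this assay reports only a limit, > 40000 nM, namely (the limit of > 40000 nM in this assay, at which 1 of the 3 values shown sits). Compound 3 `C#Cc1nc(C(=O)OCC)cs1` differs from compound 2 by hydrogen in place of methyl on a triple-bonded carbon, and in this assay compound 3 gives 2670 nM, so the step is an at least 14-fold lower number from compound 2 to compound 3 (1.17 log units; beyond the scatter). Compound 4 `C#CC1=Nc2ccccc2C(C)(C)O1` arises from compound 1 by the same change, (hydrogen in place of methyl on a triple-bonded carbon), at a place described in the same words. A step of comparable size is expected, an 11-fold lower number from compound 1 to compound 4 (1.02 log units; beyond the scatter). This expectation rests on the measured step of an at least 14-fold lower number from compound 2 to compound 3 (1.17 log units; beyond the scatter), though the cores differ and that earlier step rests on a limit. Compound 4 is therefore estimated at 800 nM, between 200 nM and 4000 nM.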

Compound 4, half-maximal inhibitory concentration: 890 nM
Compound 4: the middle estimate sits 1.1-fold (0.05 log units) below what was measured; measured number inside the range.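

In this assay the change from prop-1-yn-1-yl to ethynyl gives a 9.4-fold lower number from compound 1 to compound 4 (0.97 log units; beyond the scatter) and so lowers the number on the core of compound 1, as it did on the core of compound 2. This shows the same direction on these two cores, but whether the size of the step carries over stays unsettled: the same change on two cores in this assay, an at least 14-fold lower number (1.17 log units; beyond the scatter) from compound 2 to compound 3 and a 9.4-fold lower number (0.97 log units; beyond the scatter) from compound 1 to compound 4; the limit leaves it open whether they differ. Two pairs show nothing about a third core, so no general rule for this series follows from them.

The compounds shown leave open how a longer chain such as but-1-yn-1-yl would read in this assay on either core. They also leave open how an amine or a carboxylic acid in place of the ethynyl group would read.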